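Thiazoline for oxazoline on the bis-sulfonyl vinyl scaffold

This account rests on a few compounds, and the source may have more. Where it says the series, first, only, none or still open, it means among the compounds named here.

Compound 1 `Cc1ccc(S(=O)(=O)/C=C/S(=O)(=O)CC2=NCCS2)cc1`: 21.7%
Compound 2 `O=S(=O)(/C=C/S(=O)(=O)c1ccc(Cl)cc1)CC1=NCCO1`: 85.5%
Compound 3 `O=S(=O)(/C=C/S(=O)(=O)c1ccccc1)CC1=NCCO1`: 82.1%

In a functional assay for inhibition, tested at 100 uM (on this read-out higher numbers stand for more inhibition at the one concentration tested (going by the name of the read-out) and lower numbers for less inhibition), compound 2 gives the highest of the three numbers; compound 3 sits close to it, with a number 3.4 percentage points lower from compound 2 to compound 3 (within the scatter), while compound 1 lies far lower. Compound 4 `O=S(=O)(/C=C/S(=O)(=O)c1ccc(Cl)cc1)CC1=NCCS1` is not yet measured. It differs from compound 2 in one place: a group of 5 heavy atoms (3 carbon, 1 nitrogen, 1 sulfur; one five-membered non-aromatic ring with 2 hetero atoms) in place of a group of 5 heavy atoms (3 carbon, 1 nitrogen, 1 oxygen; one five-membered non-aromatic ring with 2 hetero atoms), on a saturated chain carbon bound to a sulfonyl sulfur. Within the data shown here, no measured pair isolates this change. Compound 1, which carries the sulfur-containing ring, gives 21.7%, and compound 2, with the oxygen-containing ring, gives 85.5%, but those two also differ on the aromatic carbon, so the comparison is only suggestive. A drop is therefore expected, of uncertain size: the estimate is a number 40.5 percentage points lower from compound 2 to compound 4 (beyond the scatter). For compound 4 the expected value is 45%, with a range from 15% to 75%.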

Compound 4, a percentage reported as inhibition, at one concentration (the size of the read-out at that concentration, not a potency): 32.3%
Compound 4: middle estimate off by 12.7 percentage points, on the high side; the range from low to high includes it.
By their numbers in this assay, from the lowest: compound 1; then compound 4; then compounds 3 and 2 (each within the scatter of the next).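

In this assay, with the chloro group held fixed, sulfur in place of oxygen in the five-membered ring, on a saturated chain carbon bound to a sulfonyl sulfur, gives a number 53.2 percentage points lower from compound 2 to compound 4 (beyond the scatter), so this one change alone carries a large loss. With the sulfur-containing ring held fixed, chloro in place of methyl on an aromatic carbon gives a number 10.6 percentage points higher from compound 1 to compound 4 (beyond the scatter), a modest step by comparison. Nothing measured here explains the loss. Still open, going by these compounds, is whether the loss persists with other groups on the aromatic carbon, such as methoxy, and what a simple amine would give in place of the five-membered ring.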